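The source may report more compounds than this note shows. Statements on the series, on what has been measured and on what is new or still open speak of the compounds shown alone.

Among the three compounds measured in a functional assay on QG-56 cells (Homo sapiens) for antiproliferative activity (on this read-out higher numbers stand for weaker inhibition and lower numbers for stronger inhibition), compound 3 `Cn1cncc1C(O)(c1ccc(C#N)cc1)c1cc2cc([N+](=O)[O-])cc(-c3cccc(C#N)c3)c2o1` gives 22.9 nM and stands lowest; its nearest neighbour is compound 1 `COc1cccc(-c2cc(CN(C)C)cc3cc(C(O)(c4ccc(C#N)cc4)c4cncn4C)oc23)c1`, which gives 142 nM, and the furthest is compound 2 `Cn1cncc1C(O)(c1ccc(C#N)cc1)c1cc2cc([N+](=O)[O-])cc(-c3ccccc3)c2o1`, which gives 1480 nM. Compound 4 `COc1ccc(-c2cc([N+](=O)[O-])cc3cc(C(O)(c4ccc(C#N)cc4)c4cncn4C)oc23)cc1` has not yet been measured. It differs from compound 3 in one place: 4-methoxyphenyl in place of 3-cyanophenyl on an aromatic carbon. The change sits on an aromatic carbon of a six-membered aromatic ring of carbon only, part of a fused system of two rings, meta to a nitro group.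

For the measured compounds named here, only one measured step bears directly on this change. The step of a 65-fold lower number from compound 2 to compound 3 (1.81 log units; beyond the scatter) shows that the cyano on this ring carries most of the strength of compound 3. Going by the values given here, compound 4 gives that cyano up and takes a 4-methoxyphenyl instead; no measured pair shows what a methoxy does at this position, and compound 1 differs from compound 4 in more than one place, so its value can only hint that a methoxyphenyl is compatible with moderate inhibition. On that basis a clear rise in the number is expected, of roughly a 20-fold higher number from compound 3 to compound 4 (1.29 log units; beyond the scatter), though smaller than the full loss seen in compound 2. Compound 4 is therefore estimated at 450 nM, with a range from 120 nM to 1700 nM.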

Compound 4, half-maximal inhibitory concentration: 36 nM
Compound 4: the middle estimate sits 13-fold (1.10 log units) above what was measured; the measured number lies below the stated range.
By their numbers in this assay, from the lowest: compounds 3 and 4 (each within the scatter of the next); then compound 1; then compound 2.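

The added methoxy in compound 4 changes the picture: a 41-fold lower number from compound 2 to compound 4 (1.61 log units; beyond the scatter) shows that the large drop in the number is not tied to the nitrile, since a second, quite different group on the same phenyl ring also produces it. The exchange itself, a 1.6-fold higher number from compound 3 to compound 4 (0.20 log units; within the scatter), lies within the scatter, so in this assay the 3-cyanophenyl and 4-methoxyphenyl groups cannot be told apart at this place on the shared core, meta to a nitro group. Thus, across these three compounds, the unsubstituted phenyl of compound 2 stands apart from both substituted rings, and no available evidence explains this result.

The compounds shown leave open whether the nitrile and the methoxy would give similar numbers if each stood at the ring position the other occupies, since the two exchanged groups differ in both their atoms and their place on the phenyl ring. They also leave open whether an amine, a carboxylic acid or a longer alkoxy chain on this phenyl ring would give a step of similar size from compound 2.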